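The source may hold more compounds than are shown below. What is called first, only, known or untested is meant among the compounds shown, and "the series" means these compounds.

In a functional assay on the whole organism (strain albino) for inhibition, with Rattus norvegicus as the target, read by paw edema, with stated times of 1 h and 3 h, at a dose of 20 mmol/kg by the intraperitoneal route (a higher number here means a stronger effect of the compound at the dose given, a lower number a weaker effect), compound 1 `N#CC1=C(NCC(=O)O)N(c2ccccc2)C(=O)N2CCCCC(N3CCCC3)C12` gives 89.2%, compound 2 `N#CC1=C(NCC(=O)N2CCCC2)N(c2ccccc2)C(=O)N2CCCCC(N3CCCC3)C12` gives 56%, and compound 3 `COc1ccc(N/C=N/C2=C(C#N)C3C(N4CCCC4)CCCCN3C(=O)N2c2ccccc2)cc1` gives 50.2%. Compound 3 therefore holds the lowest of the three numbers: the step of a number 39 percentage points lower from compound 1 to compound 3 (beyond the scatter) separates it clearly from compound 1, whereas the step of a number 5.8 percentage points lower from compound 2 to compound 3 (within the scatter) does not separate it from compound 2. Compound 4 `CCOC(=O)C(=O)NC1=C(C#N)C2C(N3CCCC3)CCCCN2C(=O)N1c1ccccc1` differs from compound 3 in one place: a group of 8 heavy atoms (4 carbon, 1 nitrogen, 3 oxygen; no ring) in place of a group of 11 heavy atoms (8 carbon, 2 nitrogen, 1 oxygen; one six-membered aromatic ring of carbon only), on a double-bonded ring carbon The same position was changed in the steps of a number 33.2 percentage points lower from compound 1 to compound 2 (beyond the scatter) and a number 39 percentage points lower from compound 1 to compound 3 (beyond the scatter), both large and downward, while a number 5.8 percentage points lower from compound 2 to compound 3 (within the scatter) stayed within the scatter. On these data alone, nothing measured covers the entering group, so a partial return toward compound 1 is possible, but a result near compound 3 is equally open. Compound 4 is therefore expected to give 58% in this assay, between 38% and 80%. That estimate means a step of a number 7.8 percentage points higher from compound 3 to compound 4 (within the scatter).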

Compound 4, a percentage reported as inhibition, in the whole organism at one dose (the size of the read-out at that dose, not a potency): 91.5%
Compound 4: the middle estimate sits 33.5 percentage points below what was measured, and the stated range ends below it.
By their numbers in this assay, from the lowest: compounds 3 and 2 (each within the scatter of the next); then compounds 1 and 4 (each within the scatter of the next).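

In this assay, the change at this position gives a number 41.3 percentage points higher from compound 3 to compound 4 (beyond the scatter) and a number 35.5 percentage points higher from compound 2 to compound 4 (beyond the scatter), so the position that had shown only large downward steps from compound 1 can also give large upward ones. For the compounds shown here, the (ethoxycarbonyl)carbonyl group on the amine nitrogen in place of carboxymethyl gives a number 2.3 percentage points higher from compound 1 to compound 4 (within the scatter), so the free carboxylic acid of compound 1 is not the only group here that reaches that level. Nothing available accounts for this result. On these data alone, it remains open how a methyl ester or an acetyl group on that amine nitrogen would read, and whether the ethyl part of the ester counts.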